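This account rests on a few compounds, and the source may have more. Where it says the series, first, only, none or still open, it means among the compounds named here.

Measured so far in an assay on a protein complex for inhibition of CDK8/Cyclin C (Homo sapiens), with a stated time of 1 h; on this read-out higher numbers stand for weaker inhibition and lower numbers for stronger inhibition:
Compound 1, `COC1CN(C(=O)/C=C/c2ccncc2-c2ccc3ccccc3c2)C1`, gives 42.8 nM.
Compound 2, `COc1ccc(-c2cnccc2/C=C/C(=O)N2CC(OC)C2)cc1OC`, gives 1220 nM.
Compound 3, `Cn1ccc2cc(-c3cnccc3/C=C/C(=O)N3CCOCC3)ccc21`, gives 247 nM.

Among these three, compound 1 has the lowest number; its gap to compound 3 and its wider gap to compound 2 both lie beyond the usual scatter, so compound 1 is the strongest inhibitor of the set. The step followed here leads from compound 1 to compound 4, `CN(C)C(=O)/C=C/c1ccncc1-c1ccc2ccccc2c1`, which has not yet been measured. The change is dimethylamino in place of 3-methoxyazetidin-1-yl on a carbonyl carbon. Among the compounds with values here, no measured pair shows this change, so the data give no direct guide to its effect. A modest weakening in this assay is expected, a step of a 2.6-fold higher number from compound 1 to compound 4 (0.41 log units; beyond the scatter), somewhat beyond the scatter. Compound 4 is therefore estimated at 110 nM, within a range from 35 nM to 350 nM.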

Compound 4, half-maximal inhibitory concentration: 30.1 nM
The estimate for compound 4 lay 3.7-fold (0.56 log units) above the measured number; the measured number lies below the stated range.
By their numbers in this assay, from the lowest: compounds 4 and 1 (each within the scatter of the next); then compound 3; then compound 2.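

In this assay, the step of a 1.4-fold lower number from compound 1 to compound 4 (0.15 log units; within the scatter) shows that, on this carbonyl carbon, 3-methoxyazetidin-1-yl can give way to dimethylamino with the two values staying within the scatter of each other. On the core of compound 1, neither the four-membered ring nor the methoxy group of the leaving group is needed to hold inhibition at this level. Nothing at hand accounts for this result. The compounds shown leave open how far this place extends: whether diethylamino, with its longer chains, or 4-methylpiperazin-1-yl, with a further amine, would hold the same level on this core.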